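Isopentyloxy replaces methyl: working notes on cytotoxicity

The compounds below may be only part of what the source reports. "The series", "measured", "known", "first", "only" and "open" are said of these compounds alone.

In a functional assay on DLD-1 cells (Homo sapiens) for cytotoxicity, with a stated time of 48 h (a lower number here means a stronger inhibitor, a higher number a weaker inhibitor), compound 1 `CC(=O)Oc1ccc2oc(/C=C/[S+](C)[O-])cc(=O)c2c1` gives > 10000 nM as a limit of the assay, not a number. Among the compounds with values here, compound 2 `Cc1ccc2oc(/C=C/[S+](C)[O-])cc(=O)c2c1` gives 7000 nM as the only actual number so far. The next compound, compound 3 `CC(C)CCOc1ccc2oc(/C=C/[S+](C)[O-])cc(=O)c2c1`, carries isopentyloxy in place of methyl on an aromatic carbon. Within the data shown here, only one measured step bears on this change: methyl in place of acetoxy on an aromatic carbon, which is an at least 1.4-fold lower number from compound 1 to compound 2 (0.15 log units; that floor lies within the scatter) and rests on the limit of > 10000 nM in this assay, at which 1 of the 2 values shown sits, as its bound. That step sets no size to carry over, so no shift beyond the scatter is expected in this assay for compound 3. An estimated 1.2-fold lower number from compound 2 to compound 3 (0.07 log units; within the scatter) is expected, and a result reported only as a limit remains possible. Compound 3 is estimated at 6000 nM with 2500 nM to 13000 nM as the expected range.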

Compound 3, half-maximal inhibitory concentration: 4100 nM
For compound 3 the middle estimate is 1.5-fold (0.17 log units) above the measured one; low and high end bracket the measured number.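

In this assay, isopentyloxy in place of methyl on this aromatic carbon gives a 1.7-fold lower number from compound 2 to compound 3 (0.23 log units; within the scatter), so the position accepts the much larger group without a shift that can be told from the scatter. Isopentyl in place of acetyl on the same oxygen gives the first step in the series beyond the scatter, an at least 2.4-fold lower number from compound 1 to compound 3 (0.38 log units; beyond the scatter). Compound 1 gives > 10000 nM, which is a limit and not a number, so this step sets only a floor and its full size stays open: the limit of > 10000 nM in this assay, at which 1 of the 3 values shown sits.

With only methyl and isopentyloxy giving actual numbers at this position, no trend with chain size can be drawn. A methoxy group, a longer alkoxy chain, an amine or a carboxylic acid on this carbon would test how far the position's tolerance extends.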